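Swapping Chloro for Bromo in Three Measured Compounds

The source may report more compounds than this note shows. Statements on the series, on what has been measured and on what is new or still open speak of the compounds shown alone.

Compound 1, `Clc1ccc(OCC2=NCCO2)cc1`: 12%
Compound 2, `Brc1ccccc1OCC1=NCCO1`: 40%
Compound 3, `Clc1ccccc1OCC1=NCCO1`: 80%

All three were tested in a toxicity assay on the whole organism with Rattus norvegicus as the target, at a dose of 400 mg/kg by the oral route; a lower number here means a weaker effect, a higher number a stronger effect of the compound at the dose given. Compound 1 gives the lowest number of the three, with compound 2 and compound 3 both beyond the scatter above it. Within the data shown here, the only single-point step among the measured compounds is a number 40 percentage points lower from compound 3 to compound 2 (beyond the scatter), that is bromo in place of chloro on an aromatic carbon. The difference between the core of compound 1 and that of compound 3 is not broken down here.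

Compound 4, `Brc1ccc(OCC2=NCCO2)cc1`, has not been measured. It differs from compound 1 by bromo in place of chloro on an aromatic carbon. This is the same kind of change as from compound 3 to compound 2, but not the same: the earlier place reads "ortho to a group of 7 heavy atoms", this one "para to a group of 7 heavy atoms". Because compound 1 already sits at 12%, a drop as large as the earlier one cannot appear in this assay. A smaller drop is expected, a number 4 percentage points lower from compound 1 to compound 4 (within the scatter). Compound 4 is estimated to give 8%, between 0% and 30%.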

Compound 4, a percentage reported as activity, at one dose (the size of the read-out at that dose, not a potency): 15%
The estimate for compound 4 lay 7 percentage points below the measured number; low and high end bracket the measured number.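

In this assay, putting bromo in place of chloro on the core of compound 1 gives a number 3 percentage points higher from compound 1 to compound 4 (within the scatter), so on this core the swap leaves no readable change. The same swap does not behave alike on the two cores: the same change on two cores in this assay, a number 40 percentage points lower (beyond the scatter) from compound 3 to compound 2 and a number 3 percentage points higher (within the scatter) from compound 1 to compound 4, 43 percentage points apart, beyond the scatter of two such steps. This shows that the step seen on one core cannot be carried to the other in this series, but it does not show why, as the two pairs differ in both the core and the place of the halogen on the ring.

Only chloro and bromo appear at these places. From the compounds shown here alone, how an amine, a carboxylic acid or a longer chain there would read on either core remains open.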